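The compounds below may be only part of what the source reports. "The series", "measured", "known", "first", "only" and "open" are said of these compounds alone.

Compound 1 `O=C(c1ccncc1)N1N=C(c2cc3ccccc3o2)CC1c1ccco1` carries a furan-2-yl group on the saturated ring. In an ADME assay on Vero cells (Chlorocebus sabaeus) for cytotoxicity, read by MTT assay, with a stated time of 72 h (a higher number here means a weaker inhibitor, a lower number a stronger inhibitor), compound 1 gives only a limit, > 208000 nM. Compound 2 `O=C(c1ccncc1)N1N=C(c2cc3ccccc3o2)CC1/C=C/c1ccccc1` differs from it by 2-phenylethenyl in place of furan-2-yl on a saturated ring carbon. In this assay compound 2 likewise gives only a limit, > 212000 nM. The step that the two limits leave unreadable from compound 1 to compound 2 therefore cannot be sized, since both values are limits, as shown by the limit of > 208000 nM in this assay, at which 1 of the 3 values shown sits, and (the limit of > 212000 nM in this assay, at which 1 of the 3 values shown sits). Compound 3 `CCn1cc(C(=O)N2N=C(c3cc4ccccc4o3)CC2c2ccco2)c(=O)c2ccc(C)nc21` has a different core; the difference between the cores of compound 1 and compound 3 is not broken down here. In this assay compound 3 also gives only a limit, > 185000 nM, which is the limit of > 185000 nM in this assay, at which 1 of the 3 values shown sits. Compound 4 `CCn1cc(C(=O)N2N=C(c3cc4ccccc4o3)CC2/C=C/c2ccccc2)c(=O)c2ccc(C)nc21` is not yet measured and differs from compound 3 by 2-phenylethenyl in place of furan-2-yl on a saturated ring carbon. This is the same kind of change as from compound 1 to compound 2, but the neighbouring ring atom bears a large group rather than a (pyridin-4-yl)carbonyl group. Because compound 1 and compound 2 both sit at a limit, a step that the two limits leave unreadable from compound 1 to compound 2, the step is expected to be a step that the limit leaves unreadable from compound 3 to compound 4. Compound 4 is therefore expected to show 200000 nM, between 100000 nM and 400000 nM, most likely again as a limit.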

Compound 4, half-maximal inhibitory concentration: > 168000 nM
Compound 4 was reported as a limit; the forecaster's own chance of this, stated with the estimate: 85%; the middle value does not contradict the limit.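

In this assay compound 3 and compound 4 both stand only at limits, and no step can be read between them, any more than between compound 1 and compound 2. The compounds shown leave open at what concentration any of them reaches half-maximal inhibition, and whether 2-phenylethenyl in place of furan-2-yl changes that concentration on either core.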